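The source may report more compounds than this note shows. Statements on the series, on what has been measured and on what is new or still open speak of the compounds shown alone.

Working notes on a small set of ring-constrained amino acids tested in an assay for inhibition of alpha-N-acetylgalactosaminidase (Gallus gallus), tested at 1000 uM; a higher number here means more inhibition at the concentration tested (going by the name of the read-out), a lower number less inhibition.

Compound 1 `O=C(O)[C@H]1NCC=C[C@@H]1O` gives 25% in this assay. Compound 2 `O=C(O)[C@H]1NC[C@@H](O)[C@H](O)[C@@H]1O` gives 11% in this assay, which is the lowest of the two numbers recorded; its nearest neighbour is compound 1, whose value lies higher by a gap beyond the usual scatter of repeated measurements. For the measured compounds named here, no pair of compounds measured so far differs in only one place, so no single-change step has yet been recorded.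

Compound 3 `O=C(O)[C@H]1NC[C@H](O)[C@@H](O)[C@@H]1O` has not been measured. Its relation to compound 2 is one of configuration only: the two compounds have the same atoms and bonds and differ only in configuration as drawn: 2 of 4 stereo elements differ; a stereocentre at a saturated ring carbon is drawn R in compound 2 and S in compound 3; a stereocentre at a saturated ring carbon is drawn S in compound 2 and R in compound 3

Going by the values given here, with no recorded step to lean on, and with both measured compounds showing only modest inhibition at the tested concentration, the expectation for compound 3 is a step from compound 2 of a number 7 percentage points higher from compound 2 to compound 3 (within the scatter), a change that would not clearly exceed the usual scatter. Compound 3 is therefore estimated at 18% in this assay, with a plausible range from 4% to 45%.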

Compound 3, a percentage reported as inhibition, at one concentration (the size of the read-out at that concentration, not a potency): 0.2%
The estimate for compound 3 lay 17.8 percentage points above the measured number; the whole stated range lies above it.
By their numbers in this assay, from the lowest: compound 3; then compound 2; then compound 1.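

For the compounds shown here, the first single-change reading comes from swapping the configuration at two saturated ring carbons, one drawn R becoming S and the other drawn S becoming R: in this assay this gives a number 10.8 percentage points lower from compound 2 to compound 3 (beyond the scatter). Configuration alone is therefore enough to move the read-out at the tested concentration, with no group entering or leaving, and the shift can be placed on the stereochemistry because nothing else separates the pair: the fact that compounds 2 and 3 differ only in the configuration as drawn. In this assay compound 3 gives 0.2%, so this drawn configuration leaves essentially no inhibition at the concentration tested, where compound 2 still shows a small but readable number.

Going by these compounds, the two ring carbons change together, and the share of each in the step cannot be told from this pair, so the effect of inverting either one alone remains open. Also open, on these data alone, is how the read-out in this assay responds when the carboxylic acid gives way to a methyl ester or a primary amide on either configuration.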